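Sulfonyl aryl swap: chlorothiazole in place of tolyl

A few compounds are considered here, and "the series" means these few. Any claim that something is new, unique, unknown or untested is made for them only; others in the source may bear on it.

Measured compounds, by readout in a functional assay on DLD-1 cells (Homo sapiens) for antiproliferative activity, read by CellTiter-Glo, with a stated time of 72 h; on this read-out higher numbers stand for weaker inhibition and lower numbers for stronger inhibition:
compound 1 `CC1CCN(C2CCN(S(=O)(=O)c3cccnc3Cl)CC2)CC1` gives > 5000 nM, a limit of the assay rather than a number.
compound 2 `CC1CCN(C2CCN(S(=O)(=O)c3cnc(Cl)s3)CC2)CC1` gives 1800 nM.
compound 3 `Cc1cccc(S(=O)(=O)N2CCC(N3CCC(C)CC3)CC2)c1` gives 25 nM.

Compound 3 holds the lowest number of the two numbers in hand; the nearest is compound 2, with a 72-fold lower number from compound 2 to compound 3 (1.86 log units; beyond the scatter). Compound 1 stands only at the limit (the limit of > 5000 nM in this assay, at which 1 of the 3 values shown sits).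

The next compound, compound 4 `Cc1nc(Cl)sc1S(=O)(=O)N1CCC(N2CCC(C)CC2)CC1`, differs from compound 3 in one place: 2-chloro-4-methyl-1,3-thiazol-5-yl in place of 3-methylphenyl on a sulfonyl sulfur.

Among the measured compounds shown here, two measured steps bear on this change. Going from the chloropyridyl to the chlorothiazolyl group gave an at least 2.7-fold lower number from compound 1 to compound 2 (0.44 log units; beyond the scatter), and the step away from the chlorothiazolyl group to the tolyl group gave a 72-fold lower number from compound 2 to compound 3 (1.86 log units; beyond the scatter). Compound 4 carries a chlorothiazolyl group that matches compound 2 except for the added methyl, so the reverse of that large step is expected to reappear, perhaps softened by the methyl. Compound 4 is therefore expected to show a substantially higher number, a 32-fold higher number from compound 3 to compound 4 (1.51 log units; beyond the scatter), and its estimated value is 800 nM with a likely range of 200 nM to 4000 nM.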

Compound 4, half-maximal inhibitory concentration: 1.6 nM
Beside the measured number, compound 4's estimate is 500-fold (2.70 log units) above it, outside the stated range (below it).
By their numbers in this assay, from the lowest: compound 4; then compound 3; then compound 2. At a limit, above all of these: compound 1.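

In this assay, methyl in place of hydrogen on an aromatic carbon of the chlorothiazolyl group gives a 1100-fold lower number from compound 2 to compound 4 (3.05 log units; beyond the scatter), so in this pair that single methyl decides the outcome on the sulfonyl sulfur. The methylated group also overtakes the 3-methylphenyl group, with a 16-fold lower number from compound 3 to compound 4 (1.19 log units; beyond the scatter), and the chloropyridyl group, with an at least 3100-fold lower number from compound 1 to compound 4 (3.49 log units; beyond the scatter), so the order of compound 2 and compound 3 does not carry over to the methylated thiazole. Compound 1 stands at a limit and not at a number: the limit of > 5000 nM in this assay, at which 1 of the 4 values shown sits.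

On these data alone, whether an ethyl or a trifluoromethyl group on that ring carbon would match the methyl remains open. So does whether the chlorine of compound 4 could give way to an amine or a methoxy group and keep this read-out.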